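Replacing the bromophenyl ring of compound 3 with pyridin-3-yl

A few compounds are considered here, and "the series" means these few. Any claim that something is new, unique, unknown or untested is made for them only; others in the source may bear on it.

Measured so far in a functional assay on the whole organism (strain Albino Wistar) for inhibition, with Rattus norvegicus as the target, read by paw edema, with stated times of 1 h and 3 h, at a dose of 10 mg/kg by the oral route; a lower number here means less inhibition, a higher number more inhibition at the dose given (going by the name of the read-out):
Compound 1 `Clc1cccc(-n2cc(CSc3nc4ccccc4s3)nn2)c1` gives 35%.
Compound 2 `Clc1ccc(-n2cc(CSc3nc4ccccc4s3)nn2)cc1` gives 50%.
Compound 3 `Brc1ccc(-n2cc(CSc3nc4ccccc4s3)nn2)cc1` gives 75%.

All three compounds share one core and differ only in the aromatic ring attached to a ring nitrogen. Compound 3 stands highest of the three: its nearest neighbour is compound 2, and the gap is a number 25 percentage points higher from compound 2 to compound 3 (beyond the scatter), while the step of a number 40 percentage points higher from compound 1 to compound 3 (beyond the scatter) is larger still. Moving the chlorine from one position to another gives a number 15 percentage points higher from compound 1 to compound 2 (beyond the scatter).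

Compound 4 `c1cncc(-n2cc(CSc3nc4ccccc4s3)nn2)c1` has not yet been measured. It differs from compound 3 in one place: pyridin-3-yl in place of 4-bromophenyl on an aromatic nitrogen

Two of the measured steps bear on this. The step of a number 25 percentage points higher from compound 2 to compound 3 (beyond the scatter) shows that the number is higher with bromo than with chloro at the same position, so taking the bromine away should cost something. The step of a number 15 percentage points higher from compound 1 to compound 2 (beyond the scatter) shows that the ring substitution pattern also matters. Among the measured compounds shown here, no measured step covers a nitrogen entering the ring itself, so that part of the change is untested here. On balance a drop beyond the scatter is expected for compound 4, estimated as a number 35 percentage points lower from compound 3 to compound 4 (beyond the scatter), giving an expected value of 40% with a range from 20% to 62%.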

Compound 4, a percentage reported as inhibition, in the whole organism at one dose (the size of the read-out at that dose, not a potency): 64%
Compound 4: middle estimate off by 24 percentage points, on the low side; the measured number lies above the stated range.
By their numbers in this assay, from the lowest: compound 1; then compound 2; then compound 4; then compound 3.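

In this assay, this position on the ring nitrogen turns out not to depend on a halogen: pyridin-3-yl carries none, yet it gives up only a limited part of the bromo result (a number 11 percentage points lower from compound 3 to compound 4 (beyond the scatter)) and stands above both chlorinated compounds (a number 14 percentage points higher from compound 2 to compound 4 (beyond the scatter); a number 29 percentage points higher from compound 1 to compound 4 (beyond the scatter)). The earlier compounds shown here showed only a rise from chloro to bromo, and this change shows that a ring with one hetero atom, one hydrogen-bond acceptor and one heavy atom fewer than 4-bromophenyl can still take second place among the four. Nothing available here explains why this change costs so little.

Still open is whether the place of the ring nitrogen matters, as pyridin-2-yl and pyridin-4-yl are not among the compounds shown, and whether plain phenyl with no halogen would fall nearer compound 3 or compound 1. Also open, from the compounds shown here alone, is what a ring bearing fluoro, methoxy, an amine or a carboxylic acid would give at this position.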